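Removing the benzoyl amide from the hexanoate ether series

A few compounds are considered here, and "the series" means these few. Any claim that something is new, unique, unknown or untested is made for them only; others in the source may bear on it.

Measured compounds:
Compound 1 `CCOC(=O)CCCCCOc1cccc(CN(C(=O)c2ccccc2)C(C)C)c1`: in an ADME assay on HepG2 cells (Homo sapiens) for cytotoxicity, read by CellTiter-Glo and resazurin assay, with a stated time of 72 h (a lower number here means that less compound is needed, a higher number that more compound is needed for the effect), compound 1 gives > 26000 nM, which is a limit of the assay and not a number.
Compound 2 `CCOC(=O)CCCCCOc1cccc(CN(C(=O)c2ccc(-c3cccc(O)c3)cc2)C(C)C)c1`: in this assay compound 2 gives > 26000 nM, again a limit rather than a number.

Within the data shown here, compound 1 therefore stands only at a limit in this assay, and the one further value shown is a limit as well. Among the measured compounds shown here, the single step recorded, a step that the two limits leave unreadable from compound 1 to compound 2, cannot be read in size or direction because both values sit at the limit of > 26000 nM in this assay, at which 2 of the 2 values shown sit.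

Compound 3 `CCOC(=O)CCCCCOc1cccc(CNC(C)C)c1` differs from compound 1 by hydrogen in place of benzoyl on an amine nitrogen. For the measured compounds named here, no measured step bears on this change; the only recorded step is unreadable, so no direction beyond the scatter can be drawn from the data. The step from compound 1 to compound 3 is therefore expected to be about a step that the limit leaves unreadable from compound 1 to compound 3, that is, no change beyond the scatter. Compound 3 is estimated to give 30000 nM in this assay, within a range from 13000 nM to 80000 nM, and most likely to be reported again only as a limit.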

Compound 3, half-maximal effective concentration: > 26000 nM
Compound 3 gave a limit, no number; the forecaster's own chance of this, stated with the estimate: 75%; the middle value is on the limit's open side.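

Compound 3 gives only a limit, so the step from compound 1 to compound 3 cannot be read in size or direction: the limit of > 26000 nM in this assay, at which 3 of the 3 values shown sit. The compounds shown leave open what numerical value any member of this series would give in this assay, and how the benzoyl group affects it.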